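A Furan for a Thiophene on the Shared Core

The compounds below may be only part of what the source reports. "The series", "measured", "known", "first", "only" and "open" are said of these compounds alone.

Compound 1 `N#Cc1ccc(N2CCc3cc(-c4cncnc4)ccc32)cc1C(F)(F)F`: "not determined" (no result reported)
Compound 2 `N#Cc1ccc(N2CCc3cc(-c4cnc5ccccc5c4)ccc3C2)cc1C(F)(F)F`: > 30000 nM
Compound 3 `CCN(c1ccc(C#N)c(Cl)c1)c1cc(-c2cccs2)ccc1C`: "not determined" (no result reported)

Three compounds have been submitted to a functional assay on VCaP cells (Homo sapiens) for antiproliferative activity, read by CCK-8 assay, with a stated time of 6 days; a higher number here means a weaker inhibitor, a lower number a stronger inhibitor. Compound 1 gives "not determined" (no result reported). Compound 2 reaches only a limit of the assay, > 30000 nM. Compound 3 gives "not determined" (no result reported), so no number places it. Within the data shown here, the only value shown anywhere is the limit recorded as the limit of > 30000 nM in this assay, at which 1 of the 3 values shown sits. Compound 4 `CCN(c1ccc(C#N)c(Cl)c1)c1cc(-c2ccoc2)ccc1C` differs from compound 3 by furan-3-yl in place of thiophen-2-yl on an aromatic carbon. Among the measured compounds shown here, no step between two measured compounds exists here, so nothing in this assay indicates a direction; the exchange of one five-membered aromatic ring with 1 hetero atom for another is expected to move the value no further than the usual scatter. Compound 4 is therefore estimated at 15000 nM, within a range from 1500 nM to 100000 nM, with a real chance that only a limit is reported.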

Compound 4, half-maximal inhibitory concentration: 4010 nM
For compound 4 the middle estimate is 3.7-fold (0.57 log units) above the measured one; measured number inside the range.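

Among these compounds, compound 3 has no reported result in this assay, so no step from it to compound 4 can be read. What the exchange of thiophen-2-yl for furan-3-yl does to the value stays open, and nothing shown here bears on the result of compound 4.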